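Fluorophenylethyl Replaces Hydroxybenzyl on the Amine Nitrogen

The compounds below may be only part of what the source reports. "The series", "measured", "known", "first", "only" and "open" are said of these compounds alone.

Compound 1 `Cc1ccc2cc(C(C)N(Cc3ccc(F)cc3)Cc3ccc(C(C)C)cc3)c(=O)[nH]c2c1`: in a toxicity assay on MDCK cells (Canis lupus familiaris) for cytotoxicity, read by crystal violet staining, with a stated time of 48 h (on this read-out lower numbers stand for higher toxicity in this test and higher numbers for lower toxicity in this test), compound 1 gives > 33000 nM, a limit of the assay.
Compound 2 `Cc1ccc2[nH]c(=O)c(CN(Cc3ccc(O)cc3)Cc3ccc(C(C)(C)C)cc3)cc2c1`: compound 2 gives 4900 nM.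
Compound 3 `CCc1ccc2[nH]c(=O)c(CN(Cc3ccc(O)cc3)Cc3ccc(C(C)(C)C)cc3)cc2c1`: compound 3 gives > 10000 nM, again a limit.

Compound 3 therefore stands only at a limit, and one further value is a limit too (the limit of > 10000 nM in this assay, at which 1 of the 3 values shown sits, (the limit of > 33000 nM in this assay, at which 1 of the 3 values shown sits)). Among the compounds with values here, the single measured step, an at least 2.0-fold higher number from compound 2 to compound 3 (0.30 log units; that floor lies within the scatter), touches a different place and lies within the scatter. Compound 4 `CCc1ccc2[nH]c(=O)c(CN(Cc3ccc(C(C)(C)C)cc3)[C@H](C)c3ccc(F)cc3)cc2c1` differs from compound 3 by 1-(4-fluorophenyl)ethyl in place of 4-hydroxybenzyl on an amine nitrogen. Within the data shown here, no measured step covers this exchange; compound 1, which also carries a 1-(4-fluorophenyl)ethyl group, sits at a limit. Compound 4 is thus expected to remain at or beyond the limit, with the expected step that the limit leaves unreadable from compound 3 to compound 4 being no change beyond the scatter. The estimate for compound 4 is 20000 nM (7000 nM to 60000 nM).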

Compound 4, half-maximal cytotoxic concentration: > 5000 nM
Compound 4: a limit, no number; the forecaster's own chance of this, stated with the estimate: 70%; the middle value does not contradict the limit.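

Compound 3 and compound 4 both stand at limits in this assay, so no step can be read between them. From the compounds shown here alone, how far 1-(4-fluorophenyl)ethyl in place of 4-hydroxybenzyl shifts the half-maximal cytotoxic concentration, if at all, stays open.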